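Removing One Methyl From the Aryl Group of Compound 2

The source may hold more compounds than are shown below. What is called first, only, known or untested is meant among the compounds shown, and "the series" means these compounds.

Compound 1 `CC(C)n1ncc2c(C(=O)Nc3cccnc3)cccc21` — > 40000 nM in a functional assay on PC-3 cells (Homo sapiens) for inhibition, read by MTT assay, with a stated time of 72 h (on this read-out higher numbers stand for weaker inhibition and lower numbers for stronger inhibition), a limit of the assay.
Compound 2 `Cc1ccc(-n2cc(CNC(=O)c3cccc4c3cnn4C(C)C)nn2)cc1C` — 23400 nM.
Compound 3 `CC(C)n1ncc2c(C(=O)NCc3cn(-c4ccc([N+](=O)[O-])cc4)nn3)cccc21` — > 40000 nM, a limit of the assay.

Among these three compounds, compound 2 is the only one with an actual number in this assay; the other two values are limits (the limit of > 40000 nM in this assay, at which 2 of the 3 values shown sit). Compound 4 `Cc1ccc(-n2cc(CNC(=O)c3cccc4c3cnn4C(C)C)nn2)cc1` has not yet been measured. It differs from compound 2 by hydrogen in place of methyl on an aromatic carbon of a six-membered aromatic ring of carbon only, ortho to a methyl group and meta to a large group.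

Among the compounds with values here, the one measured step that touches the same aryl group is an at least 1.7-fold higher number from compound 2 to compound 3 (0.23 log units; that floor lies within the scatter), where 4-nitrophenyl replaced 3,4-dimethylphenyl. That step, a limit, reached only a floor within the scatter, so it gives little guidance, and it concerns a larger exchange than the loss of a single methyl. The expectation for compound 4 is therefore a step no larger than the scatter, if anything toward a higher number, expressed as a 1.3-fold higher number from compound 2 to compound 4 (0.11 log units; within the scatter). Compound 4 is estimated at 30000 nM, within a range from 14000 nM to 60000 nM.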

Compound 4, half-maximal inhibitory concentration: 39000 nM
Compound 4: the middle estimate sits 1.3-fold (0.11 log units) below what was measured; the measured number falls inside the stated range.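

In this assay, 4-methylphenyl in place of 3,4-dimethylphenyl gives a 1.7-fold higher number from compound 2 to compound 4 (0.22 log units; within the scatter), so the methyl ortho to a methyl group and meta to a large group can be lost without a step that stands clear of the scatter. Within the data shown here, this is the first single-methyl change on this aryl group, and unlike the step from compound 2 to compound 3, it joins two actual numbers. Methyl in place of nitro on an aromatic carbon reads as an at least 1.0-fold lower number from compound 3 to compound 4 (0.01 log units; that floor lies within the scatter), a floor resting on a limit that sets no order between the two compounds: the limit of > 40000 nM in this assay, at which 2 of the 4 values shown sit.

The compounds shown leave open whether the remaining methyl matters as well, since no plain phenyl group appears among them. They also leave open how a methoxy group, an amine or a carboxylic acid on this aryl group would read.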